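The source may report more compounds than this note shows. Statements on the series, on what has been measured and on what is new or still open speak of the compounds shown alone.

Compound 1 `C#CCOc1ccc2c(=O)c(-c3cc(OC)c(OC)cc3OC)coc2c1` — in a functional assay on HUVEC cells (Homo sapiens) for antiproliferative activity, read by MTT assay, with a stated time of 24 h (a lower number here means a stronger inhibitor, a higher number a weaker inhibitor), compound 1 gives > 10000 nM, a limit of the assay.
Compound 2 `COc1cc(OC)c(-c2coc3cc(OCc4ccc(Br)cc4)ccc3c2=O)cc1OC` — in this assay compound 2 gives > 10000 nM, likewise a limit.

Compound 1 therefore stands at the limit, and nothing more than a limit is known for it; the same holds for compound 2, as the evidence the limit of > 10000 nM in this assay, at which 2 of the 2 values shown sit, states. The step that the two limits leave unreadable from compound 1 to compound 2 cannot be sized, because both ends are limits. Compound 3 `COc1cc(OC)c(-c2coc3cc(OCc4cccc(F)c4)ccc3c2=O)cc1OC` differs from compound 1 by 3-fluorophenyl in place of ethynyl on a saturated chain carbon bound to an oxygen on an aromatic ring. Among the compounds with values here, the one measured step that bears on this change is the one to compound 2, where a benzyl group also enters at the same place, and it gave no readable size. The expectation for compound 3 in this assay is thus a value at or beyond the limit, with no step beyond the scatter readable. Compound 3 is expected to give 15000 nM, between 6000 nM and 60000 nM. The step that the limit leaves unreadable from compound 1 to compound 3 is the expected one.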

Compound 3, half-maximal inhibitory concentration: 5300 nM
Compound 3: middle estimate off by 2.8-fold (0.45 log units), on the high side, outside the stated range (below it).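

Within the data shown here, at this place, on a saturated chain carbon bound to an oxygen on an aromatic ring, compound 3 gives the first reading in this assay that is a number and not a limit. The step is an at least 1.8-fold lower number from compound 1 to compound 3 (0.27 log units; that floor lies within the scatter), and against 4-bromophenyl it is an at least 1.8-fold lower number from compound 2 to compound 3 (0.27 log units; that floor lies within the scatter), so neither change is shown to go beyond the scatter, and the step between the other two compounds cannot be read. The reading therefore rests on a single number, while the rest of the series stays at the limit: the limit of > 10000 nM in this assay, at which 2 of the 3 values shown sit.

The compounds shown leave open whether the fluorine, its place on the ring or the ring itself matters, since 3-fluorophenyl and 4-bromophenyl differ in both halogen and position. On these data alone, how an unsubstituted phenyl, an amine or a longer chain would read at this place also remains open.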